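Chloro on the Fused Core of Compound 2

The compounds below may be only part of what the source reports. "The series", "measured", "known", "first", "only" and "open" are said of these compounds alone.

Of the compounds shown here, three with a shared core have so far been measured in a functional assay on SMMC-7721 cells (Homo sapiens) for inhibition, read by MTT assay, with a stated time of 72 h, tested at 10 uM; on this read-out higher numbers stand for a stronger effect at the one concentration tested and lower numbers for a weaker effect. Compound 1 `Clc1ccc2c(O/N=C(/C=C/c3ccc(OCc4ccccc4Cl)cc3)\C=C\c3ccccn3)ncnc2c1` gives 84.7% in this assay, compound 2 `Clc1ccc(COc2ccc(/C=C/C(/C=C/c3ccccn3)=N/Oc3ncnc4ccccc34)cc2)cc1` gives 94.4%, and compound 3 `Clc1ccc(COc2ccc(/C=C/C(/C=C/c3ccccn3)=N/Oc3ncnc4ccccc34)cc2)c(Cl)c1` gives 89.6%. Among the measured compounds shown here, compound 2 sits at the top of these three numbers, but neither neighbour lies beyond the scatter from it: the one step that differs in a single place, a number 4.8 percentage points lower from compound 2 to compound 3 (within the scatter), and compound 1, which differs from compound 2 in more than one place, shows a number within the scatter of compound 2 as well.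

The next compound, compound 4 `Clc1ccc(COc2ccc(/C=C/C(/C=C/c3ccccn3)=N/Oc3ncnc4cc(Cl)ccc34)cc2)cc1`, is derived from compound 2 by a single change, (chloro in place of hydrogen on an aromatic carbon). For the measured compounds named here, the only measured step of the same kind, chloro in place of hydrogen on an aromatic carbon, is the one from compound 2 to compound 3, and it stayed within the scatter, though it sat on a different ring. Compound 1, which carries chloro on the same fused ring as compound 4, also lies within the scatter of compound 2. No step beyond the scatter is therefore expected for compound 4 in this assay, with an expected change of a number 4.4 percentage points lower from compound 2 to compound 4 (within the scatter). Compound 4 is expected to give about 90%, estimated between 80% and 97%.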

Compound 4, a percentage reported as inhibition, at one concentration (the size of the read-out at that concentration, not a potency): 88.1%
For compound 4 the middle estimate is 1.9 percentage points above the measured one; the range from low to high includes it.
By their numbers in this assay, from the lowest: compounds 1, 4, 3 and 2 (each within the scatter of the next).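

With the new step, chloro in place of hydrogen on an aromatic carbon of the fused ring, read as quinazolin-4-yl to 7-chloroquinazolin-4-yl, has its own single-place result in this assay: a number 6.3 percentage points lower from compound 2 to compound 4 (within the scatter), so this position, like the ring reached in a number 4.8 percentage points lower from compound 2 to compound 3 (within the scatter), shows no change beyond the scatter when chloro enters. Among the compounds shown here, compound 4 also gives the first single-place comparison among compounds that carry 7-chloroquinazolin-4-yl, where 4-chlorophenyl in place of 2-chlorophenyl gives a number 3.4 percentage points higher from compound 1 to compound 4 (within the scatter), so the placing of chloro on that outer ring does not separate these two compounds either. Nothing shown offers an explanation for these numbers.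

The compounds shown leave open whether a group other than chloro at this place on the fused ring, such as methoxy, an amine or a carboxylic acid, would give a step beyond the scatter. They also leave open whether these compounds, all within the scatter of compound 2 at the one concentration tested, would separate from one another in a full concentration series.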